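The source may report more compounds than this note shows. Statements on the series, on what has been measured and on what is new or still open speak of the compounds shown alone.

Compound 1 `CC(=O)NCCC1CCN(S(=O)(=O)NC(=O)NC[C@@H]2C[C@@H]3C=C[C@@H]2C3)CC1` and compound 2 `Cc1ncsc1C(=O)NCCC1CCN(S(=O)(=O)NC(=O)NC[C@@H]2C[C@@H]3C=C[C@@H]2C3)CC1` share one core and differ only in the group on a carbonyl carbon. In a functional assay on the whole organism (blood) with Rattus norvegicus as the target, with stated times of 24 h and 1 h, at a dose of 5 mg/kg by the intraperitoneal route (a lower number here means a weaker effect, a higher number a stronger effect of the compound at the dose given), compound 1 gives 18%, and compound 2 gives 11%. Compound 2 thus stands beside compound 1, separated by a number 7 percentage points lower from compound 1 to compound 2 (within the scatter), so the two cannot be told apart on these numbers. Compound 3 `Cc1cccc(C(=O)NCCC2CCN(S(=O)(=O)NC(=O)NC[C@@H]3C[C@@H]4C=C[C@@H]3C4)CC2)n1` carries the next change at that same carbonyl carbon: 6-methylpyridin-2-yl in place of 4-methyl-1,3-thiazol-5-yl on a carbonyl carbon. Among the compounds with values here, the one measured step that bears on this is a number 7 percentage points lower from compound 1 to compound 2 (within the scatter), a swap of the group on the carbonyl carbon that brought no shift beyond the scatter. Exchanging one aromatic ring for another there is therefore expected to give a number 1 percentage points higher from compound 2 to compound 3 (within the scatter), with no movement beyond the scatter. Compound 3 is estimated to give 12% in this assay, within a range from 2% to 25%.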

Compound 3, a percentage reported as activity, at one dose (the size of the read-out at that dose, not a potency): 20%
Compound 3: the middle estimate sits 8 percentage points below what was measured, and the stated range covers the measured number.
By their numbers in this assay, from the lowest: compounds 2, 1 and 3 (each within the scatter of the next).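

In this assay, replacing the five-membered ring with the six-membered one gives a number 9 percentage points higher from compound 2 to compound 3 (within the scatter), and replacing the small methyl group with 6-methylpyridin-2-yl gives a number 2 percentage points higher from compound 1 to compound 3 (within the scatter). With this third group on the carbonyl carbon, methyl, 4-methyl-1,3-thiazol-5-yl and 6-methylpyridin-2-yl cannot be told apart, so neither ring size nor the presence of a ring separates these compounds on these numbers. Nothing available here explains why these groups read alike.

As far as these compounds go, whether a ring carrying a carboxylic acid or an amine, or a longer chain in place of methyl, would move the read-out beyond the scatter stays open. From the compounds shown here alone, the read-out also comes from a single dose, so it remains open whether these compounds would separate at other doses.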